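The compounds below may be only part of what the source reports. "The series", "measured", "known", "first", "only" and "open" are said of these compounds alone.

Series so far in a functional assay on MCF7 cells (Homo sapiens) for cytotoxicity; on this read-out higher numbers stand for weaker inhibition of growth and lower numbers for stronger inhibition of growth
- compound 1 `COc1ccc(NS(=O)(=O)c2c(F)c(F)c(F)c(F)c2Br)cc1` gives 39 nM
- compound 2 `COc1ccc(NS(=O)(=O)c2cc(F)c(F)c(F)c2F)cc1` gives 120 nM
- compound 3 `COc1ccc(NS(=O)(=O)c2cc(F)c(Cl)c(F)c2F)cc1` gives 44000 nM

Compound 2 holds the middle of the three numbers, second highest, with compound 1 lower and compound 3 higher. The gaps on either side are very unequal: a 3.1-fold higher number from compound 1 to compound 2 (0.49 log units; beyond the scatter) and a 370-fold higher number from compound 2 to compound 3 (2.56 log units; beyond the scatter).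

The next compound is compound 4 `COc1ccc(NS(=O)(=O)c2cc(F)c(F)c(F)c2)cc1`, which differs from compound 2 by hydrogen in place of fluoro on an aromatic carbon. This is hydrogen in place of fluoro on an aromatic carbon, ortho to a large group.

Among the compounds with values here, no measured step makes this exact swap. The closest is hydrogen in place of bromo, a 3.1-fold higher number from compound 1 to compound 2 (0.49 log units; beyond the scatter), which is modest and raises the number. The other step, chloro in place of fluoro, is not the same kind of change, but a 370-fold higher number from compound 2 to compound 3 (2.56 log units; beyond the scatter) shows that one halogen change in the shared core can be large. Together these two steps point to a higher number, meaning weaker inhibition of growth, with a size more likely above the modest step than as large as the big one, and with wide uncertainty.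

The expected step is a 17-fold higher number from compound 2 to compound 4 (1.22 log units; beyond the scatter).

For compound 4 the estimated value is 2000 nM, with an expected range from 250 nM to 20000 nM.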

Compound 4, concentration for 50% growth inhibition: 2000 nM
The estimate for compound 4 equals the measured number at the digits printed; measured number inside the range.
By their numbers in this assay, from the lowest: compound 1; then compound 2; then compound 4; then compound 3.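

In this assay, hydrogen in place of fluoro on this aromatic carbon, ortho to a large group, gives a 17-fold higher number from compound 2 to compound 4 (1.22 log units; beyond the scatter) and so weakens inhibition of growth. This position therefore shows that removing one fluoro from the core of compound 2 has a large effect on the read-out, whereas the only earlier replacement of a halogen by hydrogen, a 3.1-fold higher number from compound 1 to compound 2 (0.49 log units; beyond the scatter), was modest. Loss of a halogen is thus not uniformly modest in this small set, and the fluoro-to-hydrogen step joins the chloro-for-fluoro step, a 370-fold higher number from compound 2 to compound 3 (2.56 log units; beyond the scatter), as a second large change from compound 2. Each of these two steps swaps a single atom on the shared core.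

It remains open whether the fluoro is specifically preferred on this carbon, since the compounds shown carry only fluoro or hydrogen there, with no chloro, methyl, hydroxyl or amine at that place to show how the read-out follows other groups. Nothing in the available data accounts for the size of this step.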